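A few compounds are considered here, and "the series" means these few. Any claim that something is new, unique, unknown or untested is made for them only; others in the source may bear on it.

Measured so far in a functional assay on A549 cells (Homo sapiens) for cytotoxicity, read by MTT assay, with a stated time of 48 h (on this read-out higher numbers stand for weaker inhibition and lower numbers for stronger inhibition), are these compounds:

Compound 1 `COc1cccc(-n2cc(COc3ccc(/C=C4\C[C@]5(C)[C@@H](CC/C=C(\C)CC/C=C(\C)CCC=C(C)C)[C@](C)(O)CC[C@H]5C(C)(C)C4=O)cc3)nn2)c1` gives 45700 nM
Compound 2 `CC(C)=CCC/C(C)=C/CC/C(C)=C/CC[C@@H]1[C@@]2(C)C/C(=C\c3ccc(OCc4cn(-c5ccc(Cl)cc5)nn4)cc3)C(=O)C(C)(C)[C@@H]2CC[C@@]1(C)O` gives 83200 nM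
Compound 3 `CC(C)=CCC/C(C)=C/CC/C(C)=C/CC[C@@H]1[C@@]2(C)C/C(=C\c3ccc(OCc4cn(-c5cccc(C(F)(F)F)c5)nn4)cc3)C(=O)C(C)(C)[C@@H]2CC[C@@]1(C)O` gives 23200 nM

Compound 3 stands at the low end of these three numbers, clearly apart from compound 2 but not from compound 1. Compound 4 `CC(C)=CCC/C(C)=C/CC/C(C)=C/CC[C@@H]1[C@@]2(C)C/C(=C\c3ccc(OCc4cn(-c5c(Cl)cc([N+](=O)[O-])cc5Cl)nn4)cc3)C(=O)C(C)(C)[C@@H]2CC[C@@]1(C)O` keeps the shared core and differs from compound 3 at one place, where 2,6-dichloro-4-nitrophenyl replaces 3-(trifluoromethyl)phenyl on an aromatic nitrogen 2,6-dichloro-4-nitrophenyl in place of 3-(trifluoromethyl)phenyl on an aromatic nitrogen of the five-membered ring. Among the compounds with values here, three measured steps concern this same group. Both a 1.8-fold higher number from compound 1 to compound 2 (0.26 log units; within the scatter) and a 2.0-fold lower number from compound 1 to compound 3 (0.29 log units; within the scatter) are small, and only a 3.6-fold lower number from compound 2 to compound 3 (0.55 log units; beyond the scatter) is a modest step. Within the data shown here, no measured compound carries the entering group, so support for any forecast is thin. Changes here have moved the number only modestly and compound 3 sits at the low end, so a slight rise is expected in this assay but no step beyond the scatter. The expected step is a 1.6-fold higher number from compound 3 to compound 4 (0.21 log units; within the scatter) on this estimate. Compound 4 is estimated at 38000 nM with an expected range from 15000 nM to 95000 nM in this assay.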

Compound 4, half-maximal inhibitory concentration: 34700 nM
The estimate for compound 4 lay 1.1-fold (0.04 log units) above the measured number, within the range that was stated.
By their numbers in this assay, from the lowest: compounds 3, 4, 1 and 2 (each within the scatter of the next, the first and the last beyond it).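

In this assay, 2,6-dichloro-4-nitrophenyl on the aromatic nitrogen gives a 1.5-fold higher number from compound 3 to compound 4 (0.17 log units; within the scatter) and a 1.3-fold lower number from compound 1 to compound 4 (0.12 log units; within the scatter), so a phenyl carrying two chlorines and a nitro group stays within the scatter of both the 3-(trifluoromethyl)phenyl and the 3-methoxyphenyl compounds. Only the change from 4-chlorophenyl, a 2.4-fold lower number from compound 2 to compound 4 (0.38 log units; beyond the scatter), goes beyond the scatter, so compound 2 now stands apart from both compound 3 and compound 4, though not from compound 1. Nothing available explains these differences among the groups at this position.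

As far as these compounds go, all four compounds keep a substituted phenyl on the aromatic nitrogen, so it remains open whether a simple alkyl chain, or a phenyl bearing an amine or a carboxylic acid, would move the number further. The compounds shown also cannot separate the part played by the two chlorines from that of the nitro group, which a phenyl carrying only the nitro group could address.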